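Hydrazone series: methyl on the aromatic nitrogen of compound 2

The source may hold more compounds than are shown below. What is called first, only, known or untested is meant among the compounds shown, and "the series" means these compounds.

Of the compounds shown here, two of the shared core have been measured in a functional assay on MDA-MB-231 cells (Homo sapiens) for cytotoxicity; on this read-out higher numbers stand for weaker inhibition and lower numbers for stronger inhibition. Compound 1 `COc1ccc(Cn2cc(/C=N\NC(=O)c3c[nH]c4ccccc34)c3cc(OC)ccc32)cc1` gives 9800 nM in this assay. Compound 2 `O=C(N/N=C\c1cn(Cc2ccc(Cl)cc2)c2cc(F)ccc12)c1c[nH]c2ccccc12` gives 5300 nM in this assay, the lowest number of the two, but its gap to compound 1 lies within the scatter, so the two cannot be told apart on these numbers. Compound 3 `Cn1cc(C(=O)N/N=C\c2cn(Cc3ccc(Cl)cc3)c3cc(F)ccc23)c2ccccc21` has not yet been measured in this assay. It differs from compound 2 in one place: methyl in place of hydrogen on an aromatic nitrogen. Among the compounds with values here, no step between measured compounds bears on this change, and the two measured values sit within the scatter of each other, so nothing shows which way such a change moves the read-out. The expected step is therefore small, a 1.1-fold higher number from compound 2 to compound 3 (0.05 log units; within the scatter), within the scatter and with no direction favoured. Compound 3 is estimated at 6000 nM in this assay, within a range from 2500 nM to 15000 nM.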

Compound 3, half-maximal inhibitory concentration: > 100000 nM
Compound 3 gave a limit, no number (the forecaster's own chance of this, stated with the estimate: 10%); at least 16-fold (1.22 log units) between middle value and limit.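

In this assay compound 3 gives > 100000 nM, a limit of the assay and not a number. Within the data shown here, the change from 1H-indol-3-yl to 1-methyl-1H-indol-3-yl is the first single-place step, and its result is large: an at least 18-fold higher number from compound 2 to compound 3 (1.27 log units; beyond the scatter). The earlier compounds both carry hydrogen on this aromatic nitrogen and so said nothing about the position, whereas this step shows that the read-out is sensitive to replacing that hydrogen with a single methyl; the step can be stated only as a bound because compound 3 sits at the limit: the limit of > 100000 nM in this assay, at which 1 of the 3 values shown sits.

The compounds shown leave open whether an ethyl group, a longer chain or an acetyl group on this nitrogen would read like methyl, and whether methyl on the same nitrogen of compound 1 would move the read-out as it does on compound 2. They also give no measured property that would explain the step, so its cause remains unknown, and the true size of the step remains undefined.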